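The source may report more compounds than this note shows. Statements on the series, on what has been measured and on what is new or still open speak of the compounds shown alone.

Measured in a functional assay on MCF7 cells (Homo sapiens) for cytotoxicity; on this read-out lower numbers stand for stronger inhibition and higher numbers for weaker inhibition:
- Compound 1 `COc1ccc(/C=C/c2cc(OC)c(OC)c(OC)c2)cc1B(O)O`: 470 nM
- Compound 2 `COc1cc(/C=C/C(=O)c2cc(OC)c(OC)c(OC)c2)ccc1B(O)O`: 900 nM

Compound 2, at 900 nM, and compound 1, at 470 nM, lie within the usual scatter of each other, so these two numbers cannot rank them. Compound 3 `COc1cc(/C=C/C(=O)c2cc(OC)c(OC)c(OC)c2)ccc1O` differs from compound 2 in one place: one oxygen atom in place of a group of 3 heavy atoms (1 boron, 2 oxygen; no ring), on an aromatic carbon. One oxygen atom, as a hydroxy group, stands in place of a group of 3 heavy atoms (1 boron, 2 oxygen; no ring), on an aromatic carbon. Among the compounds with values here, no measured step serves as a guide, but the expected change in this assay is a 2.2-fold higher number from compound 2 to compound 3 (0.35 log units; beyond the scatter), a modest move towards weaker inhibition. Compound 3 is estimated at 2000 nM, with an expected range of 400 nM to 10000 nM.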

Compound 3, half-maximal inhibitory concentration: 110 nM
Beside the measured number, compound 3's estimate is 18-fold (1.26 log units) above it, and the stated range ends above it.
By their numbers in this assay, from the lowest: compound 3; then compounds 1 and 2 (each within the scatter of the next).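

In this assay, a hydroxy group in place of the boron-bearing group of 3 heavy atoms gives an 8.2-fold lower number from compound 2 to compound 3 (0.91 log units; beyond the scatter) and so shows that, in this pair, boron is not needed at this aromatic carbon for strong inhibition. The simpler, smaller group is the better of the two here. No measurement at hand explains why the step is this large.

Going by these compounds, whether an amine or a carboxylic acid on this carbon would match the hydroxy group remains open. So does whether the same exchange on compound 1 would give a similar step.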